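The compounds below may be only part of what the source reports. "The series", "measured", "known", "first", "only" and "open" are said of these compounds alone.

Measured in a functional assay on MCF7 cells (Homo sapiens) for antiproliferative activity, read by MTT assay, with a stated time of 72 h; a lower number here means a stronger inhibitor, a higher number a weaker inhibitor:
- compound 1 `CCCCCCCCCCCCCCNC[C@@H]1OC[C@H](N)[C@H]1O`: 8830 nM
- compound 2 `CCCCCCCNC[C@@H]1OC[C@H](N)[C@H]1O`: > 128000 nM, a limit
- compound 3 `CCCCCCCCNC[C@@H]1OC[C@H](N)[C@H]1O`: > 128000 nM, a limit

Compound 3 gives no number, only (the limit of > 128000 nM in this assay, at which 2 of the 3 values shown sit). Compound 4 `CCCCCCCCCCNC[C@@H]1OC[C@H](N)[C@H]1O` differs from it by one change: ethyl in place of hydrogen on a saturated chain carbon, eight bonds along the chain from an amine nitrogen. Going by the values given here, two measured steps bear on this. Taking away hexyl gave an at least 14-fold higher number from compound 1 to compound 3 (1.16 log units; beyond the scatter), and taking away heptyl gave an at least 14-fold higher number from compound 1 to compound 2 (1.16 log units; beyond the scatter). Both are large and beyond the scatter, whereas a step that the two limits leave unreadable from compound 2 to compound 3 tells nothing. Ethyl restores only part of that hexyl, so a moderate move toward a lower number is expected, and the value may still sit at the limit. The expected step is an at least 2.5-fold lower number from compound 3 to compound 4 (0.40 log units; beyond the scatter). The estimate for compound 4 is 50000 nM, with an expected range from 18000 nM to 128000 nM.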

Compound 4, half-maximal inhibitory concentration: 42700 nM
Compound 4: middle estimate off by 1.2-fold (0.07 log units), on the high side; the range from low to high includes it.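

In this assay adding ethyl to the chain of compound 3 gives the first real number among these shorter chains (an at least 2.9-fold lower number from compound 3 to compound 4 (0.47 log units; beyond the scatter)), and propyl on the chain of compound 2 does the same (an at least 2.9-fold lower number from compound 2 to compound 4 (0.47 log units; beyond the scatter)). The chain of compound 1 still does better (a 4.8-fold higher number from compound 1 to compound 4 (0.68 log units; beyond the scatter)), so the number keeps falling over the added butyl rather than dropping all at once. Compound 2 and compound 3 each give a limit, not a number, so the first two steps are minimum sizes only: the limit of > 128000 nM in this assay, at which 2 of the 4 values shown sit.

Going by these compounds, whether a chain longer than that of compound 1 lowers the number further stays open. So does the effect of a hydroxyl or an amine at the far end of the chain.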